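This account rests on a few compounds, and the source may have more. Where it says the series, first, only, none or still open, it means among the compounds named here.

Measured so far:
Compound 1 `CCN(Cc1cccnc1)C(=O)COc1ccc(C)cc1` — in an assay on HEK293 cells for agonist activity at transient receptor potential cation channel subfamily M member 8 (Homo sapiens), read by fluorescence and calcium flux, with a stated time of 15 min (a higher number here means that more compound is needed for the effect, a lower number that less compound is needed), compound 1 gives 15400 nM.
Compound 2 `CCCc1ccc(OCC(=O)N(CC)Cc2cccs2)cc1` — in this assay compound 2 gives 1810 nM.
Compound 3 `CCN(Cc1cccs1)C(=O)COc1ccc(C)cc1O` — in this assay compound 3 gives 8 nM.

Among these three numbers compound 2 holds the second highest. Compound 1 sits nearest to it, with a higher number that lies beyond the usual scatter, so more of compound 1 is needed for the same effect. Compound 3 is far away on the other side, with a much lower number, again beyond the scatter, and needs the least compound of the three.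

The next compound, compound 4 `CCN(Cc1cccs1)C(=O)COc1ccc(C(=O)O)cc1`, is built from compound 2 by one change: carboxy in place of propyl on an aromatic carbon. Going by the values given here, no measured pair in this set differs in exactly this way, so there is no directly comparable step to lean on. The expectation rests on the fact that compound 2 already gives a fairly high number and that a carboxy replaces a propyl on the aromatic ring.

The step from compound 2 to compound 4 in this assay is expected to be a 4.4-fold higher number from compound 2 to compound 4 (0.65 log units; beyond the scatter), toward a higher number, beyond the scatter. Compound 4 is therefore estimated at 8000 nM, within a range from 1500 nM to 40000 nM.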

Compound 4, half-maximal effective concentration: "not active" (no number reported)
The entry for compound 4 holds no number; no gap can be computed for the estimate.
By their numbers in this assay, from the lowest: compound 3; then compound 2; then compound 1.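

In this assay, going by these compounds alone, compound 4 is reported as not active, with no number, so no step from compound 2 to compound 4 can be read. Nothing available explains this result. The compounds shown leave open how large the change is when carboxy replaces propyl, and how other groups at that place would behave.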